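Amine methylation carried from one measured pair to the next

The source may hold more compounds than are shown below. What is called first, only, known or untested is meant among the compounds shown, and "the series" means these compounds.

Measured so far in an assay on membranes from brain for displacement of a labelled ligand from Sigma non-opioid intracellular receptor 1 (Cavia porcellus), read by scintillation counting, with a stated time of 120 min; on this read-out higher numbers stand for weaker inhibition and lower numbers for stronger inhibition:
compound 1 `c1ccc(CCCCNC2CCc3ccsc3CC2)cc1` gives 62 nM
compound 2 `CN(CCCCc1ccccc1)C1CCc2ccsc2CC1` gives 17 nM
compound 3 `OCc1cc2c(s1)CCC(NCCCc1ccccc1)CC2` gives 61 nM

Compound 1 and compound 2 differ by methyl in place of hydrogen on an amine nitrogen, and the step was a 3.6-fold lower number from compound 1 to compound 2 (0.56 log units; beyond the scatter). Compound 4 `CN(CCCc1ccccc1)C1CCc2cc(CO)sc2CC1` differs from compound 3 by methyl in place of hydrogen on an amine nitrogen. The place around the amine nitrogen reads the same for both pairs, so this is the same change. The difference between the core of compound 1 and the core of compound 3 is not broken down here; the values of compound 1 and compound 3 lie within the scatter of each other. The expectation rests on a single earlier pair: because the change gave a 3.6-fold lower number from compound 1 to compound 2 (0.56 log units; beyond the scatter), a step of like size is expected from compound 3 to compound 4, a 3.2-fold lower number from compound 3 to compound 4 (0.51 log units; beyond the scatter). Compound 4 is therefore expected near 19 nM in this assay, estimated between 8 nM and 45 nM.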

Compound 4, inhibition constant: 6.4 nM
The estimate for compound 4 lay 3.0-fold (0.47 log units) above the measured number; measured number outside the range, below it.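

In this assay methyl in place of hydrogen on the amine nitrogen again gave a lower number, with a 9.5-fold lower number from compound 3 to compound 4 (0.98 log units; beyond the scatter) on the core of compound 3, the same direction as on the core of compound 1. The sizes of the two steps cannot be told apart: the same change on two cores in this assay, a 3.6-fold lower number (0.56 log units; beyond the scatter) from compound 1 to compound 2 and a 9.5-fold lower number (0.98 log units; beyond the scatter) from compound 3 to compound 4, 2.6-fold (0.42 log units) apart, within the scatter of two such steps. This shows agreement in direction and size on these two cores only; it does not show that the step would carry to a further core, and it gives no reason for the step.

Still open, going by these compounds, is how an ethyl group in place of the methyl on this nitrogen would read. Also open, on these data alone, is whether the same step would hold with a carboxylic acid in place of the hydroxymethyl group.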